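The compounds below may be only part of what the source reports. "The series", "measured", "known", "first", "only" and "open" are said of these compounds alone.

Compound 1 `CCc1ccc(-c2noc(COc3ccc(CCC(=O)O)cc3)n2)cc1` stands lowest of the three numbers measured in a functional assay on CHO cells for agonist activity at Free fatty acid receptor 1 (Homo sapiens), read by FLIPR and calcium flux, in the presence of a further agent that is not named here (on this read-out higher numbers stand for an effect only at larger amounts of compound and lower numbers for an effect already at smaller amounts), where compound 1 gives 210 nM. Compound 2 `Cc1cc(-c2noc(COc3ccc(CCC(=O)O)cc3)n2)ccc1F` gives 2120 nM, and compound 3 `O=C(O)CCc1ccc(OCc2nc(-c3cccc(Br)c3)no2)cc1` gives 1260 nM. The two steps away from compound 1 are modest rises: a 10-fold higher number from compound 1 to compound 2 (1.00 log units; beyond the scatter) and a 6.0-fold higher number from compound 1 to compound 3 (0.78 log units; beyond the scatter). Between the other two, a 1.7-fold lower number from compound 2 to compound 3 (0.23 log units; within the scatter) lies within the scatter. Compound 4 `O=C(O)CCc1ccc(OCc2nc(-c3ccc(C(F)(F)F)cc3)no2)cc1` differs from compound 1 by trifluoromethyl in place of ethyl on an aromatic carbon. Because a 10-fold higher number from compound 1 to compound 2 (1.00 log units; beyond the scatter) and a 6.0-fold higher number from compound 1 to compound 3 (0.78 log units; beyond the scatter) both went up when the ethyl group was replaced, a rise of comparable size is expected here, a 4.8-fold higher number from compound 1 to compound 4 (0.68 log units; beyond the scatter). Compound 4 is therefore estimated at 1000 nM, with a range from 350 nM to 3000 nM.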

Compound 4, half-maximal effective concentration: 610 nM
Compound 4: middle estimate off by 1.6-fold (0.21 log units), on the high side; low and high end bracket the measured number.
By their numbers in this assay, from the lowest: compound 1; then compound 4; then compounds 3 and 2 (each within the scatter of the next).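

With the ring position held fixed, this is a clean swap of one group para to a large group: trifluoromethyl in place of ethyl gives a 2.9-fold higher number from compound 1 to compound 4 (0.46 log units; beyond the scatter) in this assay. At this place, then, ethyl gives the lower number of the two, and the four-heavy-atom trifluoromethyl group still keeps the effect at a number below those of compounds 2 and 3. No available evidence accounts for this difference. As far as these compounds go, what stays open is whether a longer chain such as propyl, or a methoxy group, at the same place would match compound 1 or give a lower number.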